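This account rests on a few compounds, and the source may have more. Where it says the series, first, only, none or still open, it means among the compounds named here.

Among the measured compounds shown here, compound 1 `C=CCc1cc(C(=O)CC)c(O)cc1OCCCCC#N` gives 77% in an assay on isolated protein for inhibition of leukotriene B4 receptor 1 (Homo sapiens), tested at 10 uM (on this read-out lower numbers stand for less inhibition and higher numbers for more inhibition at the one concentration tested (going by the name of the read-out)), while compound 2 `C=CCc1cc(C(=O)CCCCCCCCC)c(O)cc1OCCCCC#N` gives 10%, the lowest of the two numbers; the only measured step, a number 67 percentage points lower from compound 1 to compound 2 (beyond the scatter), shows that lengthening the chain on the carbonyl carbon cuts inhibition sharply. Compound 3 `C=CCc1cc(C(=O)c2ccccc2)c(O)cc1OCCCCC#N` differs from compound 2 by phenyl in place of nonyl on a carbonyl carbon. This step bears on the same carbonyl position as the measured one, and the entering group is smaller than the one leaving, so a rise back toward compound 1 is expected, though not the full way. The estimate for compound 3 is 45%, range 20% to 72%, a step of a number 35 percentage points higher from compound 2 to compound 3 (beyond the scatter).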

Compound 3, a percentage reported as inhibition, at one concentration (the size of the read-out at that concentration, not a potency): 33%
The estimate for compound 3 lay 12 percentage points above the measured number; the measured number falls inside the stated range.
By their numbers in this assay, from the lowest: compound 2; then compound 3; then compound 1.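

In this assay phenyl in place of nonyl gives a number 23 percentage points higher from compound 2 to compound 3 (beyond the scatter) and phenyl in place of ethyl gives a number 44 percentage points lower from compound 1 to compound 3 (beyond the scatter) on the same carbonyl carbon. This position therefore takes an aromatic ring with inhibition that ranks under the ethyl compound and over the nonyl compound, so a ring does not restore the level of the ethyl compound. No measurement at hand gives a reason for this order.
Still open, from the compounds shown here alone, is how inhibition changes with a butyl chain on this carbonyl carbon, where the fall from ethyl to nonyl begins. Also open, going by these compounds, is how a benzyl group or an amine there would compare with phenyl.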